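Dropping the fluoro: little change expected

The source may report more compounds than this note shows. Statements on the series, on what has been measured and on what is new or still open speak of the compounds shown alone.

Compound 2 `COc1ccc(-c2cc(C(=O)Nc3nc4ccc(F)cc4s3)nc3cc(-c4ccccc4)nn23)cc1OC` stands highest of the two numbers seen so far in a functional assay on ACHN cells (Homo sapiens) for cytotoxicity, read by MTT assay, with a stated time of 48 h (a higher number here means a weaker inhibitor, a lower number a stronger inhibitor), where compound 2 gives 8120 nM. Its nearest neighbour is compound 1 `COc1ccc(-c2cc(C(=O)Nc3nc4ccc(Cl)cc4s3)nc3cc(-c4ccccc4)nn23)cc1OC`, which in this assay gives 7760 nM; the step of a 1.0-fold higher number from compound 1 to compound 2 (0.02 log units; within the scatter) lies within the scatter, so the two cannot be ordered against each other. Compound 3 `COc1ccc(-c2cc(C(=O)Nc3nc4ccccc4s3)nc3cc(-c4ccccc4)nn23)cc1OC` has not yet been measured. It differs from compound 2 by hydrogen in place of fluoro on an aromatic carbon. Within the data shown here, the only measured step that bears on this change is the exchange at the same aromatic carbon, a 1.0-fold higher number from compound 1 to compound 2 (0.02 log units; within the scatter), where one halogen took the place of another with no movement beyond the scatter. Among the measured compounds shown here, removing the halogen altogether is a different change, and no measured pair shows it directly, so the expectation rests on that single step alone. Compound 3 is therefore expected to give a number close to that of compound 2, with the step of a 1.0-fold lower number from compound 2 to compound 3 (0.01 log units; within the scatter) expected to stay within the scatter. The estimate for compound 3 in this assay is 8000 nM, with a range from 4000 nM to 16000 nM.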

Compound 3, half-maximal inhibitory concentration: 7940 nM
Compound 3: the middle estimate sits 1.0-fold (0.00 log units) above what was measured; the range from low to high includes it.
By their numbers in this assay, from the lowest: compounds 1, 3 and 2 (each within the scatter of the next).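

In this assay, the earlier pair had only exchanged one halogen for another, whereas compound 3 shows this aromatic carbon with no halogen at all. Removing the fluoro gives (a 1.0-fold lower number from compound 2 to compound 3 (0.01 log units; within the scatter)), and removing the chloro gives (a 1.0-fold higher number from compound 1 to compound 3 (0.01 log units; within the scatter)), so the bare 1,3-benzothiazol-2-yl group cannot be told apart from either halogenated form, and fluoro, chloro and hydrogen at this position leave the three compounds without an order. No independent measurement on these compounds bears on why this position shows so little response here.

The compounds shown cover only hydrogen and two halogens at this carbon, so it stays open whether an amine, a carboxylic acid or a longer alkyl chain there would move the number beyond the scatter. As far as these compounds go, it also stays open whether other parts of the molecule respond in the same way, since the two methoxy groups, the phenyl group and the amide link are the same in all three compounds.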